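The source may hold more compounds than are shown below. What is called first, only, known or untested is meant among the compounds shown, and "the series" means these compounds.

In a functional assay on KB 3-1 cells (Homo sapiens) for cytotoxicity, read by MTT assay, with a stated time of 72 h (on this read-out higher numbers stand for weaker inhibition and lower numbers for stronger inhibition), compound 1 `O=C1Nc2ccccc2/C1=N/NC(=S)NCc1ccccc1` gives 11700 nM and compound 2 `O=C1Nc2ccccc2/C1=N/NC(=S)Nc1ccc(F)cc1` gives 14200 nM. These two values lie within the usual scatter of each other, so compound 2 stands level with compound 1 and the two cannot be ranked. Compound 3 `O=C1Nc2ccccc2/C1=N/NC(=S)Nc1ccc(C(=O)O)cc1` keeps the rest of compound 2 but carries carboxy in place of fluoro on an aromatic carbon, para to a large group: carboxy in place of fluoro on an aromatic carbon. Among the compounds with values here, only one measured step bears on this, a 1.2-fold higher number from compound 1 to compound 2 (0.08 log units; within the scatter), and it concerns 4-fluorophenyl in place of benzyl on an amide-type nitrogen. Within the data shown here, that is a different swap, and no compound with a carboxy has been measured, so the guide is weak. A modest move in this assay towards weaker inhibition is expected, with wide uncertainty, as the estimated 1.8-fold higher number from compound 2 to compound 3 (0.25 log units; within the scatter). For compound 3 the estimated value is 25000 nM, with an expected range of 8000 nM to 80000 nM.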

Compound 3, half-maximal inhibitory concentration: > 50000 nM
Compound 3 ended at the assay's limit; the forecaster's own chance of this, stated with the estimate: 20%; middle value at least 2.0-fold (0.30 log units) from the limit.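

In this assay, this position on the aromatic ring proves sensitive to what it carries: carboxy in place of fluoro, para to a large group, gives an at least 3.5-fold higher number from compound 2 to compound 3 (0.54 log units; beyond the scatter). On these data alone, compound 3 reads > 50000 nM, which is a limit of the assay and not a number, so the full size of the step stays unknown. The earlier step, a 1.2-fold higher number from compound 1 to compound 2 (0.08 log units; within the scatter), concerned a different swap on the nitrogen, so this is the first change shown to move the number beyond the scatter, towards weaker inhibition.

As far as these compounds go, it remains open whether a methyl ester or an amine at this same position would stay close to compound 2 or also reach the limit. From the compounds shown here alone, it is equally open whether carboxy on the benzyl group of compound 1 would bring a similar move.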